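The source may report more compounds than this note shows. Statements on the series, on what has been measured and on what is new or still open speak of the compounds shown alone.

Within the data shown here, compound 2 `O=C1/C(=C/c2ccccc2Cl)Cc2ccccc21` holds the only plain number among the three values shown: in a functional assay on Molt4/C8 cells (Homo sapiens) for inhibition (on this read-out lower numbers stand for stronger inhibition and higher numbers for weaker inhibition), compound 2 gives 128000 nM. Compound 1 `COc1cccc(/C=C2\CCCc3ccccc3C2=O)c1OC` reaches only a limit in this assay, where compound 1 gives > 500000 nM. Compound 3 `O=C1/C(=C/c2ccc(Cl)cc2Cl)Cc2ccccc21` also reaches only a limit in this assay, where compound 3 gives > 500000 nM. Among the measured compounds shown here, the single measured step, an at least 3.9-fold higher number from compound 2 to compound 3 (0.59 log units; beyond the scatter), concerns a second chloro entering on an aromatic carbon (the limit of > 500000 nM in this assay, at which 2 of the 3 values shown sit). Compound 4 `Cc1ccccc1/C=C1\Cc2ccccc2C1=O` differs from compound 2 by methyl in place of chloro on an aromatic carbon. For the measured compounds named here, no measured step exchanges chloro for methyl, so this change is expected to remain within the scatter, a 1.0-fold higher number from compound 2 to compound 4 (0.01 log units; within the scatter). Compound 4 is therefore estimated at 130000 nM in this assay, between 40000 nM and 500000 nM.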

Compound 4, half-maximal inhibitory concentration: 154000 nM
For compound 4 the middle estimate is 1.2-fold (0.07 log units) below the measured one, within the range that was stated.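

In this assay, the exchange of chloro for methyl on an aromatic carbon, ortho to a large group, comes to a 1.2-fold higher number from compound 2 to compound 4 (0.08 log units; within the scatter). The earlier step showed a change from adding a second chloro, whereas this one shows that chloro and methyl cannot be told apart at this place on this read-out. Both compound 2 and compound 4 keep plain numbers.

As far as these compounds go, whether an amine or a carboxylic acid at this place would also leave the value unchanged stays open. Room for further comparison among the compounds shown is narrow: the limit of > 500000 nM in this assay, at which 2 of the 4 values shown sit.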